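Swapping Halogenated Rings on an Unmeasured Starting Point

The source may report more compounds than this note shows. Statements on the series, on what has been measured and on what is new or still open speak of the compounds shown alone.

Compound 1 `CC(=O)OC[C@H]1O[C@@H](SC(=S)C2=C(Nc3ccc(Cl)cc3Cl)CC(C)(C)CC2=O)[C@H](OC(C)=O)[C@@H](OC(C)=O)[C@@H]1OC(C)=O` is the starting point of this step, yet it has no measured number of its own: in an ADME assay on 3T3-L1 cells (Mus musculus) for cytotoxicity, read by MTT assay, with a stated time of 48 h (a lower number here means a stronger inhibitor, a higher number a weaker inhibitor), compound 1 gives "not determined" (no result reported). Its closest relative, compound 2 `CC(=O)OC[C@H]1O[C@@H](SC(=S)C2=C(Nc3ccc(Cl)cc3Cl)CC(C)(C)CC2=O)[C@H](OC(C)=O)[C@@H](OC(C)=O)[C@H]1OC(C)=O`, differs only in the configuration as drawn, a relationship captured by the fact that compounds 1 and 2 differ only in the configuration as drawn. Compound 2 returns only a limit of the assay rather than a number: in this assay compound 2 gives > 20 ug/mL. One of the three values shown thus sits at that limit, as summarised in the limit of > 20 ug/mL in this assay, at which 1 of the 3 values shown sits. A third substance, compound 3 `CC1(C)CC(=O)C(C(=S)SCCO)=C(Nc2ccc(Cl)cc2)C1`, is likewise without a result; in this assay compound 3 gives "not determined" (no result reported). Against this sparse background stands compound 4 `CC(=O)OC[C@H]1O[C@@H](SC(=S)C2=C(Nc3ccc(Br)cc3)CC(C)(C)CC2=O)[C@H](OC(C)=O)[C@@H](OC(C)=O)[C@@H]1OC(C)=O`, which has not yet been tested. The change from compound 1 to compound 4 is 4-bromophenyl in place of 2,4-dichlorophenyl on an amine nitrogen. Going by the values given here, no measured pair in this set shows what such a change does, so there is no step to lean on; the expectation is simply that compound 4 will behave much like its relatives, with no step in this assay beyond the usual scatter foreseen. Compound 4 is therefore estimated to give 25 ug/mL in this assay, within a range from 10 ug/mL to 60 ug/mL, and the result may well again be reported only as a limit.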

Compound 4, half-maximal inhibitory concentration: > 20 ug/mL
Compound 4: a limit, no number; the forecaster's own chance of this, stated with the estimate: 70%; the middle value does not contradict the limit.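

In this assay compound 4 gives > 20 ug/mL, which is a limit of the assay and not a number. Compound 1 offers no number for comparison, so no step can be read between compound 1 and compound 4. From the compounds shown here alone, what 4-bromophenyl in place of 2,4-dichlorophenyl does to the result in this assay remains open.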